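Swapping Hydroxy for Methylamino on Compound 3

A few compounds are considered here, and "the series" means these few. Any claim that something is new, unique, unknown or untested is made for them only; others in the source may bear on it.

Compound 1, `OCCCNc1ncnc2[nH]cc(-c3cccc(Cl)c3)c12`, gives 94 nM
Compound 2, `CC(=O)NC1CCN(c2ncnc3[nH]cc(-c4cccc(Cl)c4)c23)CC1`, gives 26 nM
Compound 3, `OC1CCN(c2ncnc3[nH]cc(-c4cccc(Cl)c4)c23)CC1`, gives 80 nM

All three numbers come from an assay for inhibition of serine/threonine-protein kinase 4 (Homo sapiens), read by luminescence and ADP-Glo, in the presence of a further agent that is not named here; a higher number here means a weaker inhibitor, a lower number a stronger inhibitor. Compound 3 stands second highest of the three: it sits within the scatter of compound 1, as a 1.2-fold lower number from compound 1 to compound 3 (0.07 log units; within the scatter) shows, while a 3.1-fold higher number from compound 2 to compound 3 (0.49 log units; beyond the scatter) is a modest step beyond the scatter. Compound 4, `CNC1CCN(c2ncnc3[nH]cc(-c4cccc(Cl)c4)c23)CC1`, has not yet been measured; it differs from compound 3 by methylamino in place of hydroxy on a saturated ring carbon. The earlier step that bears on this is a 3.1-fold higher number from compound 2 to compound 3 (0.49 log units; beyond the scatter), which likewise set hydroxy against a group joined through nitrogen on a saturated ring carbon. Compound 4 is therefore expected to give a somewhat lower number than compound 3, with a 2.0-fold lower number from compound 3 to compound 4 (0.30 log units; within the scatter) as the estimated step. The estimate for compound 4 is 40 nM, with a range from 15 nM to 120 nM.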

Compound 4, half-maximal inhibitory concentration: 148 nM
The estimate for compound 4 lay 3.7-fold (0.57 log units) below the measured number; the whole stated range lies below it.
By their numbers in this assay, from the lowest: compound 2; then compounds 3, 1 and 4 (each within the scatter of the next).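

At this saturated ring carbon, methylamino and hydroxy cannot be told apart in this assay, with a 1.9-fold higher number from compound 3 to compound 4 (0.27 log units; within the scatter), so being joined through nitrogen is not enough to give the lower number of compound 2. The clear difference lies on the amine nitrogen, where methyl in place of acetyl gives a 5.7-fold higher number from compound 2 to compound 4 (0.76 log units; beyond the scatter). Compound 4 also stays level with the open-chain compound 1, with a 1.6-fold higher number from compound 1 to compound 4 (0.20 log units; within the scatter). Nothing measured here accounts for these numbers. From the compounds shown here alone, whether a free amine or a propionyl group on that nitrogen would match the acetamido group of compound 2 remains open.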